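The source may report more compounds than this note shows. Statements on the series, on what has been measured and on what is new or still open speak of the compounds shown alone.

Series notes. The shared core of compound 1 `COc1ccc2[nH]c(=O)c(-c3nc4ccccc4[nH]3)cc2c1`, compound 2 `Cc1cc2nc(-c3cc4ccccc4[nH]c3=O)[nH]c2cc1C` and compound 3 `O=c1[nH]c2ccccc2cc1-c1nc2cc(Br)ccc2[nH]1` is tested in a functional assay on BEL-7404 cells for cytotoxicity against BEL-7404 tumor cell line (Homo sapiens), read by MTT assay, with a stated time of 48 h; a lower number here means a stronger inhibitor, a higher number a weaker inhibitor.

Compound 1 reaches only a limit in this assay, > 100000 nM. Compound 2 likewise gives only a limit in this assay, > 100000 nM. For the measured compounds named here, compound 3 is the one compound with a number, 14500 nM in this assay. Compound 2 thus stands at the weak end of what is known: its value is a limit and not a number, and two of the three results sit at the limit of > 100000 nM in this assay, at which 2 of the 3 values shown sit. Going by the values given here, no step between measured compounds differs in one place, so nothing is known about what a small change on this core does to the read-out.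

Compound 4 `Cc1ccc2[nH]c(=O)c(-c3nc4cc(C)c(C)cc4[nH]3)cc2c1` is not yet measured. Against compound 2 the change is methyl in place of hydrogen on an aromatic carbon, a small addition with no ring and no donor or acceptor.

Among the compounds with values here, with compound 2 at a limit and no measured step to lean on, the expectation is that compound 4 stays within the scatter of compound 2 and most likely again returns only a limit. The step from compound 2 to compound 4 is expected to be about a number no higher from compound 2 to compound 4 (the limit leaves the size open), that is, none beyond the scatter. For compound 4 the estimate in this assay is 100000 nM, with a range from 30000 nM to 300000 nM.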

Compound 4, half-maximal inhibitory concentration: > 100000 nM
Compound 4: no number, only a limit (the forecaster's own chance of this, stated with the estimate: 70%); the middle value lies on the limit itself.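

In this assay compound 4 gives > 100000 nM, a limit and not a number. Compound 2 also gives only a limit, so no step can be read between compound 2 and compound 4. The compounds shown leave open whether methyl in place of hydrogen on an aromatic carbon changes the read-out on this core at all, since most results rest at one limit: the limit of > 100000 nM in this assay, at which 3 of the 4 values shown sit.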